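Swapping ethynyl for furan-3-yl on a nucleoside core

The source may report more compounds than this note shows. Statements on the series, on what has been measured and on what is new or still open speak of the compounds shown alone.

Measured so far in a functional assay on CEM-DNR-bulk cells (Homo sapiens), read by MTT assay, with a stated time of 72 h; a higher number here means a weaker inhibitor, a lower number a stronger inhibitor:
Compound 1, `CN(C)c1ncnc2c1c(-c1ccoc1)cn2[C@@H]1O[C@H](CO)[C@@H](O)[C@H]1O`. For compound 1 the result is a limit of the assay, > 20000 nM.
Compound 2, `C#Cc1cn([C@@H]2O[C@H](CO)[C@@H](O)[C@H]2O)c2ncnc(N(C)C)c12`. Compound 2 gives 240 nM.
Compound 3, `C#Cc1cn([C@@H]2O[C@H](CO)[C@@H](O)[C@H]2O)c2nc(N)nc(OC)c12`. For compound 3 the result is again a limit of the assay, > 20000 nM.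

Compound 2 and compound 1 differ in one place: furan-3-yl in place of ethynyl on an aromatic carbon. This change gives an at least 83-fold higher number from compound 2 to compound 1 (1.92 log units; beyond the scatter), and compound 1 ends at the assay ceiling, (the limit of > 20000 nM in this assay, at which 2 of the 3 values shown sit).

Compound 3 carries the same ethynyl group as compound 2, but the rest of its core is different; how the two cores differ is not broken down here.

Compound 4, `COc1nc(N)nc2c1c(-c1ccoc1)cn2[C@@H]1O[C@H](CO)[C@@H](O)[C@H]1O`, is not yet measured. It stands to compound 3 as compound 1 stands to compound 2: furan-3-yl in place of ethynyl on an aromatic carbon. The place lines of the two changes are identical word for word, so this is the same change on a different core.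

For compound 3 the starting point is already a limit of the assay, > 20000 nM. Within the data shown here, the only measured example of this change, an at least 83-fold higher number from compound 2 to compound 1 (1.92 log units; beyond the scatter), made the inhibitor much weaker. Compound 4 is therefore expected to remain at or beyond the limit of this assay, with the step from compound 3 estimated as a step that the limit leaves unreadable from compound 3 to compound 4. The estimate for compound 4 is 30000 nM, with an expected range from 15000 nM to 200000 nM, and most likely only a limit will be reported.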

Compound 4, half-maximal inhibitory concentration: > 20000 nM
Compound 4: only a limit was reported; the forecaster's own chance of this, stated with the estimate: 90%; the middle value lies beyond the limit too.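

In this assay compound 4 gives > 20000 nM, which is a limit of the assay and not a number. Compound 3 also stands at a limit, so furan-3-yl in place of ethynyl gives no readable step between compound 3 and compound 4: the limit of > 20000 nM in this assay, at which 3 of the 4 values shown sit.

The compounds shown leave open how weak compound 3 and compound 4 really are, and whether this change weakens inhibition on their core as it does from compound 2 to compound 1.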